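Extending the hydroxyalkyl chain one carbon further

This account rests on a few compounds, and the source may have more. Where it says the series, first, only, none or still open, it means among the compounds named here.

Of the compounds shown here, two sharing one core have been measured in a functional assay (Pituitary gland cell) with Rattus norvegicus as the target; on this read-out lower numbers stand for an effect already at smaller amounts and higher numbers for an effect only at larger amounts of compound. Compound 1 `CC(C)(N)CC(=O)N[C@@H]1CCc2ccccc2N(Cc2ccc(-c3ccccc3C(=O)NCCCO)cc2)C1=O` gives 0.4 uM in this assay, and compound 2 `CC(C)(N)CC(=O)N[C@@H]1CCc2ccccc2N(Cc2ccc(-c3ccccc3C(=O)NCCCCO)cc2)C1=O` gives 0.01 uM. For the measured compounds named here, compound 2 therefore stands at the lowest number of the two, and its only neighbour is compound 1, from which it is separated by a 40-fold lower number from compound 1 to compound 2 (1.60 log units; beyond the scatter).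

Compound 3 `CC(C)(N)CC(=O)N[C@@H]1CCc2ccccc2N(Cc2ccc(-c3ccccc3C(=O)NCCCCCO)cc2)C1=O` has not yet been measured. It differs from compound 2 by hydroxymethyl in place of hydroxy on a saturated chain carbon, four bonds along the chain from an amide-type nitrogen. Going by the values given here, the only step on record that bears on this change is the one of the same kind, one bond closer to the amide-type nitrogen, which read a 40-fold lower number from compound 1 to compound 2 (1.60 log units; beyond the scatter). That step was large, but it is a single observation, and nothing shows whether a second lengthening continues in the same direction, levels off, or turns back. The expectation is therefore a step of a 2.0-fold higher number from compound 2 to compound 3 (0.30 log units; within the scatter) from compound 2 to compound 3, close to no change, with wide uncertainty on both sides. On this basis compound 3 is estimated at 0.02 uM in this assay, within a range from 0.003 uM to 0.15 uM.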

Compound 3, concentration for half-maximal effect: 0.01 uM
Compound 3: the middle estimate sits 2.0-fold (0.30 log units) above what was measured; low and high end bracket the measured number.
By their numbers in this assay, from the lowest: compounds 2 and 3 (each within the scatter of the next); then compound 1.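

In this assay, the second lengthening of the hydroxyalkyl chain gives no change at the digits printed from compound 2 to compound 3 (within the scatter), so the large difference seen one bond closer to the amide-type nitrogen does not carry on at this position. Hydroxymethyl in place of hydroxy, four bonds along the chain from an amide-type nitrogen, is tolerated here but brings no further shift, and taken over both lengthenings the record reads a 40-fold lower number from compound 1 to compound 3 (1.60 log units; beyond the scatter), the same size as the first lengthening alone, a 40-fold lower number from compound 1 to compound 2 (1.60 log units; beyond the scatter), so among these three compounds the whole difference lies in that first lengthening. Nothing measured on these compounds accounts for why one added carbon matters so much and the next does not.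

As far as these compounds go, whether the level stretch shared by compound 2 and compound 3 continues with a longer chain, or turns back, remains open, as does the behaviour of a shorter chain such as 2-hydroxyethyl. From the compounds shown here alone, it is also open how much depends on the hydroxy at the chain end at all, which an amine, a carboxylic acid or a methyl ether in that place on the longer chains would begin to answer.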